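The source may report more compounds than this note shows. Statements on the series, on what has been measured and on what is new or still open speak of the compounds shown alone.

Measured compounds:
compound 1, `COc1ccc(NS(=O)(=O)c2ccc(N3CCNC3=O)cc2)cc1`: 580 nM
compound 2, `O=C1NCCN1c1ccc(S(=O)(=O)Nc2ccc(C3CCCCC3)cc2)cc1`: a limit only

Among the compounds with values here, compound 1, `COc1ccc(NS(=O)(=O)c2ccc(N3CCNC3=O)cc2)cc1`, is the one compound here with a number: in a functional assay on M21 cells (Homo sapiens) for antiproliferative activity, read by sulforhodamine B assay, with a stated time of 48 h (on this read-out lower numbers stand for stronger inhibition and higher numbers for weaker inhibition), compound 1 gives 580 nM. Compound 2, `O=C1NCCN1c1ccc(S(=O)(=O)Nc2ccc(C3CCCCC3)cc2)cc1`, carries a limit only; in this assay compound 2 gives > 1000 nM, which marks the top of the range and is not a number. Between the two stands one measured step, an at least 1.7-fold higher number from compound 1 to compound 2 (0.23 log units; that floor lies within the scatter). Because the limit of > 1000 nM in this assay, at which 1 of the 2 values shown sits, sits at the top of what the assay reports, the true size of that step is open; only its floor is known, and that floor lies within the scatter.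

Compound 3, `Cc1cccc(NS(=O)(=O)c2ccc(N3CCNC3=O)cc2)c1C`, differs from compound 1 at the sulfonamide nitrogen: 2,3-dimethylphenyl in place of 4-methoxyphenyl on a sulfonamide nitrogen. Within the data shown here, the only step that bears on it is the one from compound 1 to compound 2, where the methoxy also gave way to a carbon-only group and the number went up by at least the floor given. The 2,3-dimethylphenyl is a smaller change than the cyclohexyl, so a modest rise is expected, a 1.6-fold higher number from compound 1 to compound 3 (0.19 log units; within the scatter), with a fair chance that only a limit is returned. Compound 3 is estimated at 900 nM in this assay, within 400 nM to 2500 nM.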

Compound 3, half-maximal inhibitory concentration: 110 nM
Estimate against measurement, compound 3: 8.2-fold (0.91 log units) above; the whole stated range lies above it.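

In this assay the change on the sulfonamide nitrogen gives a 5.3-fold lower number from compound 1 to compound 3 (0.72 log units; beyond the scatter), so a carbon-only aryl group can take the place of 4-methoxyphenyl here with a gain beyond the scatter, and the hydrogen-bond acceptor that leaves with the 4-methoxyphenyl is not required for a number of this size. Compound 2 carries only a limit, > 1000 nM, and that limit gave no sign that a group without oxygen could lower the number at this part of the molecule. No measured property shown here accounts for the gain in compound 3.

The compounds shown leave open whether a single methyl group on the ring would do as well as the two in 2,3-dimethylphenyl, or whether both are needed to reach this number. They also leave open how a chlorine atom, an amine or a carboxylic acid on that same ring would compare, and whether a longer chain in place of the methyl groups would hold the number or lose it.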